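Swapping nitro for cyano: an expected small step

This account rests on a few compounds, and the source may have more. Where it says the series, first, only, none or still open, it means among the compounds named here.

Measured compounds:
compound 1 `Cc1ccc(C2=NN(c3nc(-c4ccc([N+](=O)[O-])cc4)cs3)C(c3ccc(F)cc3)C2)s1` — 16.7 ug/mL
compound 2 `Cc1ccc(-c2csc(N3N=C(c4ccc(Cl)s4)CC3c3ccc(F)cc3)n2)cc1` — a limit of the assay, > 500 ug/mL

In a functional assay on A549 cells (Homo sapiens) for antiproliferative activity, read by XTT assay, with a stated time of 24 h (a lower number here means a stronger inhibitor, a higher number a weaker inhibitor), compound 1 gives 16.7 ug/mL. Compound 2 reaches only a limit of this assay, > 500 ug/mL, so no number is known for it. Among the two values shown, compound 1 thus stands as the only true number; the other value is a limit, as described by the limit of > 500 ug/mL in this assay, at which 1 of the 2 values shown sits.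

Compound 3, `Cc1ccc(C2=NN(c3nc(-c4ccc(C#N)cc4)cs3)C(c3ccc(F)cc3)C2)s1`, differs from compound 1 in a single place: cyano in place of nitro on an aromatic carbon. Among the measured compounds shown here, no pair of measured compounds differing in one place is available, so no measured step guides this change. The step from compound 1 to compound 3 in this assay is expected to be a 1.5-fold higher number from compound 1 to compound 3 (0.18 log units; within the scatter), that is, no change beyond the usual scatter in either direction. Compound 3 is therefore estimated at 25 ug/mL, with a likely range from 8 ug/mL to 80 ug/mL.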

Compound 3, half-maximal inhibitory concentration: 322 ug/mL
The estimate for compound 3 lay 13-fold (1.11 log units) below the measured number; measured number above the stated range.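

In this assay, placing cyano where nitro stood gives a 19-fold higher number from compound 1 to compound 3 (1.29 log units; beyond the scatter), so compound 3 is clearly the weaker inhibitor. This shows that the position para to a large group is far from indifferent to what it carries: nitro and cyano share much of what is counted here, with no ring, no net charge and no hydrogen-bond donor, yet the cells tell them sharply apart. Nothing measured here explains why the step is so large.

The two compounds cannot show whether nitro is unusually favourable at this place or cyano unusually poor, and an amine or a carboxylic acid on the same aromatic carbon of the core of compound 1 would help separate these readings. On these data alone, whether the step keeps its size on a different core also remains open.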